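Replacing an aryl ring with ethyl on the ring nitrogen

A few compounds are considered here, and "the series" means these few. Any claim that something is new, unique, unknown or untested is made for them only; others in the source may bear on it.

Compound 1 `COc1ccc(OC)c(N2C(=O)CSC2c2cccc(C(=O)NCCCCc3ccccc3)c2)c1` gives 92% in a functional assay on MG-63 cells (Homo sapiens) for inhibition, read by CCK-8 assay, with a stated time of 72 h, tested at 1 uM; a higher number here means more inhibition at the concentration tested (going by the name of the read-out), a lower number less inhibition. Compound 2 `COc1cccc(OC)c1N1C(=O)CSC1c1cccc(C(=O)NCCCCc2ccccc2)c1` gives 80% in this assay, and compound 3 `CCOc1ccccc1N1C(=O)C(C)SC1c1cccc(C(=O)NCCCCc2ccccc2)c1` gives 92%. Compound 2 thus has the lowest of the three numbers; the step of a number 12 percentage points lower from compound 1 to compound 2 (beyond the scatter) separates it from compound 1, with compound 3 equally far above it.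

Compound 4 `CCN1C(=O)CSC1c1cccc(C(=O)NCCCCc2ccccc2)c1` differs from compound 2 in one place: ethyl in place of 2,6-dimethoxyphenyl on an amide-type nitrogen in a ring. Among the measured compounds shown here, only the step from compound 1 to compound 2 bears on this, and it was modest; no measured step removes the aryl ring entirely, so a further, uncertain drop is expected. Compound 4 is therefore estimated at 62%, between 35% and 85%. The expected step is a number 18 percentage points lower from compound 2 to compound 4 (beyond the scatter).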

Compound 4, a percentage reported as inhibition, at one concentration (the size of the read-out at that concentration, not a potency): 0%
Estimate against measurement, compound 4: 62 percentage points above; the measured number lies below the stated range.
By their numbers in this assay, from the lowest: compound 4; then compound 2; then compounds 1 and 3 (each within the scatter of the next).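

At this ring nitrogen, both dimethoxyphenyl groups keep high numbers in this assay but ethyl does not, giving a number 80 percentage points lower from compound 2 to compound 4 (beyond the scatter) and a number 92 percentage points lower from compound 1 to compound 4 (beyond the scatter) with no inhibition left at the concentration tested. Among these compounds, then, having a dimethoxyphenyl group rather than ethyl on this nitrogen counts for far more than which of the two dimethoxyphenyl groups it is. No measurement here accounts for this collapse.

Still open, as far as these compounds go, is whether the aromatic ring itself is needed or whether a longer chain, such as hexyl, would serve. A plain phenyl or a benzyl group on this nitrogen would help separate those two possibilities.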